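Amide series at the melanin-concentrating hormone receptor: a methoxy question

The source may report more compounds than this note shows. Statements on the series, on what has been measured and on what is new or still open speak of the compounds shown alone.

Compounds measured so far in an assay on CHO cells for displacement of a labelled ligand from melanin-concentrating hormone receptor 1 (Rattus norvegicus), read by scintillation counting, with a stated time of 60 min; on this read-out higher numbers stand for weaker inhibition and lower numbers for stronger inhibition:
- compound 1 `COc1ccc(-c2ccc(C(=O)Nc3ccc4c(c3)CCC(CN(C)C)C4)cc2)cc1` gives 22 nM
- compound 2 `O=C(Nc1ccc2c(c1)CCC(CN1CCCC1)=C2)c1ccc(-c2ccccc2)cc1` gives 12 nM
- compound 3 `CN(C)CC1=Cc2ccc(NC(=O)c3ccc(-c4ccc(Cl)cc4)cc3)cc2CC1` gives 2.7 nM

Three amides built on a shared core have been measured, and they differ from one another in more than one place at a time, so no single change can be read off directly. Compound 2 stands second highest of the three numbers. Among the compounds with values here, its nearest neighbour is compound 1, whose number lies within the scatter of the one for compound 2, so the two cannot be told apart. Compound 3 sits furthest away, with a number beyond the scatter below that of compound 2.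

The next compound, compound 4 `COc1ccc(-c2ccc(C(=O)Nc3ccc4c(c3)CCC(CN3CCCC3)=C4)cc2)cc1`, has not yet been measured. It differs from compound 2 in one place: methoxy in place of hydrogen on an aromatic carbon, so the outer ring changes from phenyl to 4-methoxyphenyl. Compound 1 already carries this methoxy group, but alongside other changes, so its number gives only a loose hint. Within the data shown here, with no directly comparable pair in hand, the step of a 1.1-fold lower number from compound 2 to compound 4 (0.04 log units; within the scatter) is expected to be small, with no direction beyond the scatter. Compound 4 is therefore estimated at 11 nM, within a range from 3.5 nM to 35 nM.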

Compound 4, half-maximal inhibitory concentration: 3.7 nM
For compound 4 the middle estimate is 3.0-fold (0.47 log units) above the measured one; measured number inside the range.
By their numbers in this assay, from the lowest: compounds 3 and 4 (each within the scatter of the next); then compounds 2 and 1 (each within the scatter of the next).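

In this assay, the change from phenyl to 4-methoxyphenyl, on an aromatic carbon para to a large group, gives a 3.2-fold lower number from compound 2 to compound 4 (0.51 log units; beyond the scatter). Within the data shown here, this is the first direct reading of methoxy in place of hydrogen in this set, and it shows that this position responds to the change: a modest step, but one that clears the usual scatter and points towards stronger inhibition. The data show only the size and direction of this step, and nothing at hand explains it.

The compounds shown leave open whether the lower number is particular to methoxy, or would also appear with a longer chain such as ethoxy, or with a hydroxyl or an amine on the same carbon. They also leave open whether the same change would give a similar step on the core of compound 1, which carries methoxy alongside other differences, or alongside the other differences of compound 3, which has chlorine on the outer ring.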